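Swapping the thiourea arm for an ethyl urea at the chloro core

This account rests on a few compounds, and the source may have more. Where it says the series, first, only, none or still open, it means among the compounds named here.

Of the compounds shown here, two have been measured in an assay for inhibition of Nitric oxide synthase, inducible (Homo sapiens), read by scintillation counting, with a stated time of 30 min, tested at 1 mM; a higher number here means more inhibition at the concentration tested (going by the name of the read-out), a lower number less inhibition. Compound 1 `CCNC(=O)NCCC(O)c1cc(OC)ccc1N` gives 26.6%. Compound 2 `CCCNC(=S)NCCC(O)c1cc(Cl)ccc1N` gives 55%, the higher of the two numbers, a gap to compound 1 that lies beyond the scatter. Compound 3 `CCNC(=O)NCCC(O)c1cc(Cl)ccc1N` is not yet measured; it differs from compound 2 in one place: a group of 5 heavy atoms (3 carbon, 1 nitrogen, 1 oxygen; no ring) in place of a group of 6 heavy atoms (4 carbon, 1 nitrogen, 1 sulfur; no ring), on an amine nitrogen. Among the measured compounds shown here, no pair of measured compounds differs in this one place alone, so the size of this step has to be judged from the two values in hand. Compound 1, which carries the same ethylcarbamoyl group on a core that is otherwise not identical, sits well below compound 2, and compound 3 is therefore expected to fall between the two, with a step of a number 20 percentage points lower from compound 2 to compound 3 (beyond the scatter) downward beyond the scatter. Compound 3 is estimated at 35%, in a range from 15% to 58%.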

Compound 3, a percentage reported as inhibition, at one concentration (the size of the read-out at that concentration, not a potency): 33.9%
For compound 3 the middle estimate is 1.1 percentage points above the measured one; measured number inside the range.
By their numbers in this assay, from the lowest: compounds 1 and 3 (each within the scatter of the next); then compound 2.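

In this assay, the ethylcarbamoyl group on the amine nitrogen in place of the sulfur-bearing group gives a number 21.1 percentage points lower from compound 2 to compound 3 (beyond the scatter) on an otherwise shared core, so this position can move the read-out beyond the scatter. With the ethylcarbamoyl group held fixed, chloro in place of methoxy on the aromatic carbon gives a number 7.3 percentage points higher from compound 1 to compound 3 (within the scatter), so this read-out does not separate those two substituents in that setting. Nothing at hand gives a reason for either step. The step at the amine nitrogen changes sulfur to oxygen and alters the carbon count together, leaving open which of the two matters; a propylcarbamoyl group or an ethylthiocarbamoyl group on the chloro core would pull them apart. On these data alone, whether methoxy and chloro also stay level alongside the sulfur-bearing group remains open too.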